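This account rests on a few compounds, and the source may have more. Where it says the series, first, only, none or still open, it means among the compounds named here.

For the measured compounds named here, compound 1 `Oc1cc2c(cc1CCCOc1ccccc1)OC(CCc1ccccc1)C2` is one of two compounds measured in an assay for inhibition of Polyunsaturated fatty acid 5-lipoxygenase (Rattus norvegicus) (a lower number here means a stronger inhibitor, a higher number a weaker inhibitor), where compound 1 gives 23 nM. Its companion, compound 2 `O=C(O)c1ccc(OCCCc2cc3c(cc2O)CC(CCc2ccccc2)O3)cc1`, carries an added carboxy group and gives 44 nM in this assay, so the step of a 1.9-fold higher number from compound 1 to compound 2 (0.28 log units; within the scatter) shows no real movement. Compound 3 `Oc1cc2c(cc1CCCOc1ccccc1)OC(CCc1ccc(Cl)cc1)C2` differs from compound 1 by chloro in place of hydrogen on an aromatic carbon. Going by the values given here, no measured step touches the phenethyl chain, and the single known step only shows that one added group left the number essentially unchanged. The step from compound 1 to compound 3 is therefore expected to stay within the scatter, a 1.1-fold higher number from compound 1 to compound 3 (0.04 log units; within the scatter). Compound 3 is estimated at 25 nM, with a range from 10 nM to 65 nM.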

Compound 3, half-maximal inhibitory concentration: 51 nM
Compound 3: middle estimate off by 2.0-fold (0.31 log units), on the low side; the range from low to high includes it.
By their numbers in this assay, from the lowest: compounds 1, 2 and 3 (each within the scatter of the next, the first and the last beyond it).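

Changing the phenethyl chain of compound 1 to 2-(4-chlorophenyl)ethyl does move the result in this assay, with a 2.2-fold higher number from compound 1 to compound 3 (0.35 log units; beyond the scatter) as a modest loss of strength. Unlike the added carboxy group of compound 2, this single chlorine atom gives a step beyond the scatter, so this place on the ring is sensitive to change. No available evidence explains the shift. Going by these compounds, it remains open whether a fluoro or methoxy group at this place would cost as much. An amine there could behave quite differently.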